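The source may hold more compounds than are shown below. What is called first, only, known or untested is meant among the compounds shown, and "the series" means these compounds.

Going by the values given here, compound 2 `COc1cccc(C(=O)NCCCOc2cccc3ccc(N)nc23)c1` stands at the lower of the two numbers so far in an assay on cells with melanin-concentrating hormone receptor 1 (Homo sapiens) as the target, read by radioligand binding (on this read-out higher numbers stand for weaker inhibition and lower numbers for stronger inhibition), where compound 2 gives 2 nM; compound 1 `CC(C)c1ccc(C(=O)NCCCOc2cccc3ccc(N)nc23)cc1` gives 60 nM. Among the compounds with values here, the one measured step, a 30-fold lower number from compound 1 to compound 2 (1.48 log units; beyond the scatter), changes the group and its place on the ring at once. Compound 3 `N#Cc1cccc(C(=O)NCCCOc2cccc3ccc(N)nc23)c1` differs from compound 2 by cyano in place of methoxy on an aromatic carbon: the methoxy leaves and a cyano enters on an aromatic carbon of the six-membered carbon ring, meta to a large group. Within the data shown here, no measured step exchanges one substituent for another at a fixed place on that ring, so the large step of a 30-fold lower number from compound 1 to compound 2 (1.48 log units; beyond the scatter) bears only loosely; it shows that the ring's substitution matters, not how a cyano compares with a methoxy. A step within or slightly beyond the scatter is expected, toward a higher number if anything. For compound 3 the expected value in this assay is 4 nM, with a range of 1 nM to 20 nM. This amounts to an expected step of a 2.0-fold higher number from compound 2 to compound 3 (0.30 log units; within the scatter).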

Compound 3, half-maximal inhibitory concentration: 3 nM
Compound 3: the middle estimate sits 1.3-fold (0.12 log units) above what was measured, within the range that was stated.
By their numbers in this assay, from the lowest: compounds 2 and 3 (each within the scatter of the next); then compound 1.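

In this assay, going by these compounds alone, the change from 3-methoxyphenyl to 3-cyanophenyl gives a 1.5-fold higher number from compound 2 to compound 3 (0.18 log units; within the scatter) and is the first exchange of one group for another at a fixed place on this ring, so at this place, meta to a large group, the read-out does not separate cyano from methoxy. The step of a 20-fold lower number from compound 1 to compound 3 (1.30 log units; beyond the scatter) shows that a second group at this place also gives a much lower number than the 4-isopropylphenyl of compound 1, although that step again changes group and place at once. No evidence on the cause of either result is available here.

An isopropyl group meta to the large group would separate the effect of the group from that of its place. From the compounds shown here alone, how an amine or a carboxylic acid at this place compares with cyano and methoxy also remains open.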